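The source may report more compounds than this note shows. Statements on the series, on what has been measured and on what is new or still open speak of the compounds shown alone.

Measured in an ADME assay on the whole organism for pharmacokinetics, with Rattus norvegicus as the target, at a dose of 1 mg/kg by the intravenous route; on this read-out lower numbers stand for slow clearance and higher numbers for fast clearance:
compound 1 `O=C(O)c1ccc(Cl)cc1CC[C@@H]1CCC[C@@H]1NC(=O)C1CCN(c2ccc(C(F)(F)F)cc2)CC1`: 16 mL/min/kg
compound 2 `O=C(O)c1ccccc1CC[C@@H]1CCC[C@@H]1NC(=O)C1CCN(c2ccc(C(F)(F)F)cn2)CC1`: 6 mL/min/kg
compound 3 `Cc1ccc(C(=O)O)c(CC[C@@H]2CCC[C@@H]2NC(=O)C2CCN(c3ccc(C(F)(F)F)cc3)CC2)c1`: 9 mL/min/kg

Compound 3 holds the second highest of the three clearance numbers; its gap to compound 2 and its gap to compound 1 both lie within the scatter, so the three compounds cannot be ranked against each other on this read-out. Going by the values given here, the only single-point step among them, a 1.8-fold lower number from compound 1 to compound 3 (0.25 log units; within the scatter), is itself within the scatter.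

Compound 4 `O=C(O)c1cccnc1CC[C@@H]1CCC[C@@H]1NC(=O)C1CCN(c2ccc(C(F)(F)F)cc2)CC1` is not yet measured in this assay. Its change from compound 3 is 3-carboxypyridin-2-yl in place of 2-carboxy-5-methylphenyl on a saturated chain carbon, two bonds along the chain from a saturated ring carbon. Among the compounds with values here, no measured pair carries this same change. Within the data shown here, the one step that alters the same ring, a 1.8-fold lower number from compound 1 to compound 3 (0.25 log units; within the scatter), stayed within the scatter, and compound 2, which differs from compound 3 in more than one place, gives a value within the scatter of compound 3. On that basis no step beyond the scatter is expected. The expected step is a 1.1-fold lower number from compound 3 to compound 4 (0.05 log units; within the scatter). Compound 4 is estimated at 8 mL/min/kg, with a range from 4 mL/min/kg to 16 mL/min/kg.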

Compound 4, clearance: 38 mL/min/kg
Estimate against measurement, compound 4: 4.8-fold (0.68 log units) below; measured number above the stated range.
By their numbers in this assay, from the lowest: compounds 2, 3 and 1 (each within the scatter of the next, the first and the last beyond it); then compound 4.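

In this assay, this place on the saturated chain carbon, two bonds along the chain from a saturated ring carbon, proves sensitive to the aromatic group it carries: 3-carboxypyridin-2-yl gives a 4.2-fold higher number from compound 3 to compound 4 (0.63 log units; beyond the scatter) and a 2.4-fold higher number from compound 1 to compound 4 (0.38 log units; beyond the scatter). Both steps lie beyond the scatter, whereas the swap of chloro for methyl on the carbon-only ring had not moved the number beyond it. No measurement shown bears on the reason for this rise.

The change replaces the carbon-only ring with a ring holding a hetero atom and also removes the methyl or chloro group, and the compounds shown do not separate these two parts. Also open, going by these compounds, is whether a fluoro group on the 3-carboxypyridin-2-yl ring, or a tetrazole in place of its carboxylic acid, would bring the number back towards that of compound 3 .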